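Thiophene in place of chlorophenyl at the dienone end

The source may hold more compounds than are shown below. What is called first, only, known or untested is meant among the compounds shown, and "the series" means these compounds.

Compound 2 `COc1cc(OC)c2c(=O)c(OCCCCOc3ccccc3/C=C/C(=O)/C=C/c3ccc(Cl)cc3)c(-c3cc(OC)c(OC)c(OC)c3)oc2c1` gives 41700 nM in a functional assay on SMMC-7721 cells (Homo sapiens) for antiproliferative activity, read by MTT assay, with a stated time of 48 h (on this read-out higher numbers stand for weaker inhibition and lower numbers for stronger inhibition), the higher of the two numbers in hand. Compound 1 `COc1cc(OC)c2c(=O)c(OCCCCOc3ccccc3/C=C/C(=O)/C=C/c3ccco3)c(-c3cc(OC)c(OC)c(OC)c3)oc2c1` gives 8480 nM in this assay. Within the data shown here, the single measured step, a 4.9-fold higher number from compound 1 to compound 2 (0.69 log units; beyond the scatter), is the only guide and runs in the opposite direction to the change now considered. Compound 3 `COc1cc(OC)c2c(=O)c(OCCCCOc3ccccc3/C=C/C(=O)/C=C/c3cccs3)c(-c3cc(OC)c(OC)c(OC)c3)oc2c1` differs from compound 2 by thiophen-2-yl in place of 4-chlorophenyl on a double-bonded chain carbon bound to a double-bonded chain carbon. A five-membered heteroaryl thus returns to the position where compound 1 carries furan-2-yl, so the step from compound 2 is expected to reverse most of the rise recorded in a 4.9-fold higher number from compound 1 to compound 2 (0.69 log units; beyond the scatter), though a full return cannot be assumed on one step. The expected step is a 3.5-fold lower number from compound 2 to compound 3 (0.54 log units; beyond the scatter), toward a lower number. The estimate for compound 3 in this assay is 12000 nM, with a range from 4500 nM to 32000 nM.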

Compound 3, half-maximal inhibitory concentration: 14900 nM
Beside the measured number, compound 3's estimate is 1.2-fold (0.09 log units) below it; the measured number falls inside the stated range.
By their numbers in this assay, from the lowest: compounds 1 and 3 (each within the scatter of the next); then compound 2.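

Thiophen-2-yl in place of 4-chlorophenyl on a double-bonded chain carbon bound to a double-bonded chain carbon gives a 2.8-fold lower number from compound 2 to compound 3 (0.45 log units; beyond the scatter) in this assay and shows that the lower numbers at this place are not confined to furan-2-yl. Between the two five-membered rings there is a 1.8-fold higher number from compound 1 to compound 3 (0.24 log units; within the scatter) and no order can be drawn, so among the three compounds shown only 4-chlorophenyl stands apart, and none goes against that reading. Nothing measured accounts for this difference.

The 4-chlorophenyl group differs from both five-membered rings in ring size and in carrying chlorine, and these compounds do not separate the two; an unsubstituted phenyl at this place would. On these data alone, how a ring nitrogen, as in pyridin-3-yl, would read here also remains open.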